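Pyrazinyl to chloropyridinyl on the amide nitrogen

The source may hold more compounds than are shown below. What is called first, only, known or untested is meant among the compounds shown, and "the series" means these compounds.

Measured compounds in a functional assay on the whole organism for inhibition, with Rattus norvegicus as the target, read by cytopathic effect and paw edema, at a dose of 100 mg/kg by the oral route; a higher number here means more inhibition at the dose given (going by the name of the read-out), a lower number less inhibition:
compound 1, `Cc1ccc(NC(=O)c2c(O)c3cccnc3n(-c3ccccc3)c2=O)cc1`, 2.2%
compound 2, `Nc1ccc(NC(=O)c2c(O)c3cccnc3n(-c3ccccc3)c2=O)cc1`, 0%
compound 3, `O=C(Nc1cnccn1)c1c(O)c2cccnc2n(-c2ccccc2)c1=O`, 21.2%

Compound 3 stands highest of the three measured numbers. Compound 4, `O=C(Nc1ccc(Cl)nc1)c1c(O)c2cccnc2n(-c2ccccc2)c1=O`, differs from compound 3 in one place: 6-chloropyridin-3-yl in place of pyrazin-2-yl on an amide-type nitrogen. Within the data shown here, the steps that bear on this change are the two that also replaced the group on the amide-type nitrogen: a number 19 percentage points higher from compound 1 to compound 3 (beyond the scatter) and a number 21.2 percentage points higher from compound 2 to compound 3 (beyond the scatter), both modest rises beyond the scatter. Neither, however, involves the 6-chloropyridin-3-yl group, and compounds 1 and 2 show that other aryl groups on this nitrogen sit near zero in this assay. Compound 4 is therefore expected to lose some of the gain, by a number 9.2 percentage points lower from compound 3 to compound 4 (within the scatter). The estimate for compound 4 is 12%, in a range from 0% to 32%.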

Compound 4, a percentage reported as inhibition, in the whole organism at one dose (the size of the read-out at that dose, not a potency): -4%
Compound 4: the middle estimate sits 16 percentage points above what was measured; measured number below the stated range.
By their numbers in this assay, from the lowest: compounds 4, 2 and 1 (each within the scatter of the next); then compound 3.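

In this assay, the gain seen with pyrazin-2-yl on the amide-type nitrogen does not carry over to 6-chloropyridin-3-yl, which also has a hetero atom in its ring (a number 25.2 percentage points lower from compound 3 to compound 4 (beyond the scatter)). The new group stays level with 4-aminophenyl (a number 4 percentage points lower from compound 2 to compound 4 (within the scatter)) and 4-methylphenyl (a number 6.2 percentage points lower from compound 1 to compound 4 (within the scatter)), leaving pyrazin-2-yl alone apart from the other three groups at this position. Nothing shown here explains this difference.

From the compounds shown here alone, the step changes the chlorine and the ring's hetero atoms together, so their shares remain open. An unsubstituted pyridin-3-yl or a chloropyrazinyl group would separate them.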